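The source may hold more compounds than are shown below. What is called first, only, known or untested is meant among the compounds shown, and "the series" means these compounds.

Working notes on the series

The shared core carries a butyl ester side chain and differs only in the group attached to the ring nitrogen. Compound 1 `CCCCOC(=O)CC1c2cccc(C)c2S(=O)(=O)N1C(=O)OC` carries a methyl carbamate there, compound 2 `CCCCOC(=O)CC1c2cccc(C)c2S(=O)(=O)N1C(=O)c1ccccc1` a benzoyl group, and compound 3 `CCCCOC(=O)CC1c2cccc(C)c2S(=O)(=O)N1C(=O)c1ccc(C#N)cc1` a 4-cyanophenyl carbonyl. In an assay on HEK-Blue hNOD1 cells for antagonist activity at Nucleotide-binding oligomerization domain-containing protein 1 (Homo sapiens), read by reporter gene assay, with stated times of 3 h and 20 h (on this read-out lower numbers stand for stronger inhibition and higher numbers for weaker inhibition), compound 1 gives "not determined" (no result reported) and compound 2 gives "not determined" (no result reported), so no comparison along the series can be drawn from them. In this assay, going by the values given here, compound 3 gives 3830 nM, which is the only number in hand; compound 3 therefore stands alone, neither strongest nor weakest, simply the sole reference point.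

Compound 4 `CCCCOC(=O)CC1c2cccc(C)c2S(=O)(=O)N1C(=O)c1ccc(C(F)(F)F)cc1` is the next entry. Relative to compound 3 the change is trifluoromethyl in place of cyano on an aromatic carbon. Among the compounds with values here, no pair of measured compounds in this set shares a single change of this kind, so there is nothing in hand that tells how such an exchange has shifted results in this assay before.

Given that, the expectation for the step from compound 3 to compound 4 is a 1.0-fold higher number from compound 3 to compound 4 (0.02 log units; within the scatter), that is, nothing beyond the usual scatter of the assay. Compound 4 is accordingly expected to give about 4000 nM in this assay, with a plausible range from 1500 nM to 12000 nM, the width reflecting the absence of any measured step to lean on.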

Compound 4, half-maximal inhibitory concentration: 1310 nM
Compound 4: middle estimate off by 3.1-fold (0.48 log units), on the high side, outside the stated range (below it).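

Going by these compounds alone, the aromatic carbon para to a large group is not silent in this assay: trifluoromethyl in place of cyano gives a 2.9-fold lower number from compound 3 to compound 4 (0.47 log units; beyond the scatter) and so provides the first readable step, one that lies beyond the scatter. The change keeps the rest of compound 3 intact, so this modest shift in inhibition belongs to the exchange of these two groups at this one place, and the substituent there can be varied without losing the read-out. No measurement in hand bears on what lies behind the shift.

Steps involving compound 1 and compound 2 cannot be read, so it remains unknown how either substituent compares with the plain benzoyl group or how the aroyl groups compare with the methyl carbamate. Also open, going by these compounds, is whether a chlorine atom, a methoxy group or an amine on the same aromatic carbon would extend or reverse this shift, and whether the same step would hold with a carboxylic acid in place of the butyl ester.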